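This account rests on a few compounds, and the source may have more. Where it says the series, first, only, none or still open, it means among the compounds named here.

In an ADME assay on the whole organism with Oryza sativa as the target, tested at 0.1 uM (on this read-out lower numbers stand for a stronger effect and higher numbers for a weaker effect at the one concentration tested), compound 1 `C[C@H](NC(=O)Nc1ccccc1C(C)(C)C)c1ccccc1` gives 101%, while compound 2 `CC(=O)c1ccccc1NC(=O)N[C@@H](C)c1ccccc1` gives 100%, the lowest of the two numbers shown, though its nearest neighbour, compound 1, sits only a step within the scatter away; that step, acetyl in place of tert-butyl on an aromatic carbon, was a number 1 percentage points lower from compound 1 to compound 2 (within the scatter). Compound 3 `C[C@H](NC(=O)Nc1ccccc1F)c1ccccc1` differs from compound 2 by fluoro in place of acetyl on an aromatic carbon. Going by the values given here, only that one measured step bears on this change, and it stayed within the scatter, so no step beyond the scatter is expected in this assay. Compound 3 is therefore estimated to give 100%, between 90% and 110%. The expected step is no change at the digits printed from compound 2 to compound 3 (within the scatter).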

Compound 3, a percentage reported as activity, at one concentration (the size of the read-out at that concentration, not a potency): 98%
Compound 3: the middle estimate sits 2 percentage points above what was measured; the measured number falls inside the stated range.
By their numbers in this assay, from the lowest: compounds 3, 2 and 1 (each within the scatter of the next).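

In this assay, fluoro in place of acetyl on an aromatic carbon gave a number 2 percentage points lower from compound 2 to compound 3 (within the scatter), and fluoro in place of tert-butyl gave a number 3 percentage points lower from compound 1 to compound 3 (within the scatter). Going by these compounds alone, this position has now carried three different groups, and no step among them lies beyond the scatter, so the read-out has not yet separated any of these groups. Nothing available accounts for this flat result. Going by these compounds, whether an amine or a carboxylic acid on this aromatic carbon would give a step beyond the scatter remains open. So does whether a change elsewhere on the shared core would.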